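The source may hold more compounds than are shown below. What is called first, only, known or untested is meant among the compounds shown, and "the series" means these compounds.

Compound 1 `COC(=O)Nc1cc(-c2cc(Cl)c(OC[C@@](C)(N)CC(C)C)cn2)ccn1` is the most stable of the three compounds measured in an ADME assay on microsomes from liver (Homo sapiens) for metabolic stability, read by LC-MS, using NADPH, with a stated time of 10 min, tested at 0.5 uM (on this read-out higher numbers stand for a more stable compound and lower numbers for a less stable compound), where compound 1 gives 96%. Its closest neighbour is compound 2 `CC(=O)Nc1cc(-c2cc(F)c(OC[C@@H](N)CC(C)C)c(F)c2)ccn1`, which in this assay gives 90%, a number six points lower and within the scatter. Furthest away is compound 3 `Cc1cc(-c2cc(Cl)c(OC[C@@](C)(N)CC(C)C)cn2)ccn1`, which in this assay gives 86%; the one measured step, a number 10 percentage points lower from compound 1 to compound 3 (within the scatter), stays within the scatter, so no real ordering among the three can be claimed.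

Compound 4 `COC(=O)Nc1cc(-c2ccc(OC[C@@](C)(N)CC(C)C)cn2)ccn1` differs from compound 1 by a single change, (hydrogen in place of chloro on an aromatic carbon). For the measured compounds named here, no measured step touches this part of the molecule: the only step on record changes a different group, and compound 2, which carries no chlorine, differs from compound 1 in several places at once, so its value shows nothing about chlorine alone. With all three numbers high and close together, no step beyond the scatter is expected in this assay; the change expected is a number 8 percentage points lower from compound 1 to compound 4 (within the scatter). Compound 4 is therefore estimated at 88%, with a range from 70% to 98%.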

Compound 4, percent of the compound remaining: 93%
Beside the measured number, compound 4's estimate is 5 percentage points below it; measured number inside the range.
By their numbers in this assay, from the lowest: compounds 3, 2, 4 and 1 (each within the scatter of the next).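

For the compounds shown here, this is the first measured step at the aromatic carbon ortho to the (2-amino-2,4-dimethylpentyl)oxy group and opposite the ring nitrogen. In this assay, hydrogen in place of chloro gives a number 3 percentage points lower from compound 1 to compound 4 (within the scatter), so compound 1 and compound 4 cannot be told apart, and the chloro group at this position is not needed for a high number in this pair. Nothing measured here explains why the two compounds match.

On these data alone, only chloro and hydrogen have been compared at this position, so the effect of a group such as methoxy or nitrile there remains open. As far as these compounds go, it is also open whether the same swap would give a similar result with methyl, as in compound 3, in place of the (methoxycarbonyl)amino group.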